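Ester Chain Length and Cytotoxicity in Two Related Cores

The compounds below may be only part of what the source reports. "The series", "measured", "known", "first", "only" and "open" are said of these compounds alone.

Compound 1, `CCCCCC(=O)O[C@]12C=CC(=O)C[C@H]1OCC2`, gives 1.8 ug/mL in a functional assay on HeLa S3 cells (Homo sapiens) for cytotoxicity; on this read-out higher numbers stand for weaker inhibition and lower numbers for stronger inhibition.
Compound 2, `CCCCCCCC(=O)O[C@]12C=CC(=O)C[C@H]1OCC2`, gives 0.8 ug/mL in this assay.
Compound 3, `CCCC(=O)O[C@]12C=CC(O)C[C@H]1OCC2`, gives 8.8 ug/mL in this assay.

Compound 1 and compound 2 share the same core and differ only in the ester chain: ethyl in place of hydrogen on a saturated chain carbon, five bonds along the chain from a carbonyl carbon. Lengthening the chain in this way gave a 2.3-fold lower number from compound 1 to compound 2 (0.35 log units; beyond the scatter), so the longer chain goes with stronger inhibition in this assay.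

Compound 3 is built on a different core, and how the core of compound 3 differs from the core of compound 1 is not broken down here. Among the three measured compounds, compound 3 shows the highest number, and its steps to compound 1 and compound 2 are both beyond the usual scatter.

Compound 4, `CCCCCC(=O)O[C@]12C=CC(O)C[C@H]1OCC2`, has not yet been measured. It differs from compound 3 by the same kind of change that separates compound 2 from compound 1: ethyl in place of hydrogen on a saturated chain carbon, three bonds along the chain from a carbonyl carbon. The place is not identical, since in compound 4 the ethyl enters three bonds along the chain from a carbonyl carbon, whereas in compound 2 it enters five bonds along the chain from a carbonyl carbon, so this is the same kind of change rather than the same change. A modest lowering of the number is expected for compound 4 because a 2.3-fold lower number from compound 1 to compound 2 (0.35 log units; beyond the scatter) shows what this kind of chain extension did on the other core. The expected step is a 2.0-fold lower number from compound 3 to compound 4 (0.29 log units; within the scatter). Compound 4 is estimated to give 4.5 ug/mL in this assay, expected to fall between 2.5 ug/mL and 9 ug/mL.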

Compound 4, half-maximal inhibitory concentration: 5.3 ug/mL
For compound 4 the middle estimate is 1.2-fold (0.07 log units) below the measured one; low and high end bracket the measured number.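

The new step is a 1.7-fold lower number from compound 3 to compound 4 (0.22 log units; within the scatter) in this assay, so on its own this chain extension cannot be told apart from the ordinary variation between repeated measurements. Set beside the earlier step, the new one does not differ from it by more than that variation, which fits the idea that this kind of chain extension behaves similarly on both cores: the same change on two cores in this assay, a 2.3-fold lower number (0.35 log units; beyond the scatter) from compound 1 to compound 2 and a 1.7-fold lower number (0.22 log units; within the scatter) from compound 3 to compound 4, 1.4-fold (0.13 log units) apart, within the scatter of two such steps. Among the compounds shown here, this does not prove that the change carries over, however: each core offers only a single pair, the ethyl enters at a different place along the chain in each pair, and the step on the second core does not clear the scatter by itself.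

The compounds shown leave open whether the trend would continue with a longer chain, or whether it would survive if the chain carried an amine or a carboxylic acid. They also leave open whether the same picture would appear on either core with further pairs of compounds, or in cells other than those used here.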